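A few compounds are considered here, and "the series" means these few. Any claim that something is new, unique, unknown or untested is made for them only; others in the source may bear on it.

Working notes on the series.

Compound 1 `CCCOc1c(C(=O)N(C)Cc2cc(C(F)(F)F)cc(C(F)(F)F)c2)c(=O)n(C)c2ccccc12` carries a propoxy group on its core and is the starting point here, but in an assay for inhibition of phosphatidylcholine:ceramide cholinephosphotransferase 2 (Mus musculus), read by mass spectrometry, with stated times of 60 min and 30 min (a higher number here means a weaker inhibitor, a lower number a stronger inhibitor), compound 1 gives "not determined" (no result reported), so there is no single number on which it stands. Going by the values given here, the only measured member is compound 2 `CCOc1cc(CN(C)C(=O)c2c(OCCCC3CCN(C(=O)OC(C)(C)C)CC3)c3ccccc3n(C)c2=O)cc(OCC)c1`, which shares the core and the amide but carries a different ether chain and a different benzyl group; in this assay compound 2 gives 51 nM. That value shows the series can reach this range but says nothing directly about the step taken here.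

Compound 3 `CN(Cc1cc(C(F)(F)F)cc(C(F)(F)F)c1)C(=O)c1c(N2CCCC2)c2ccccc2n(C)c1=O` differs from compound 1 by pyrrolidin-1-yl in place of propoxy on an aromatic carbon. Among the compounds with values here, no measured pair exists for this change, and compound 1 itself has no result, so the size and direction of the step in this assay cannot be read from the data; the working expectation is a step of no more than the usual scatter in either direction, with the direction open.

Compound 3 is therefore estimated, resting on compound 2 at 51 nM as the only anchor, at 120 nM, in the range 15 nM to 900 nM.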

Compound 3, half-maximal inhibitory concentration: 1100 nM
Beside the measured number, compound 3's estimate is 9.2-fold (0.96 log units) below it, outside the stated range (above it).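

No step can be read from compound 1 to compound 3: in this assay compound 1 gives "not determined" (no result reported), while compound 3 gives 1100 nM. The compounds shown leave open how pyrrolidin-1-yl in place of propoxy changes the value on the shared core. No supporting data bear on this result.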